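A few compounds are considered here, and "the series" means these few. Any claim that something is new, unique, unknown or untested is made for them only; others in the source may bear on it.

Compound 1 `Cc1nc(N[C@H](C)c2ccccc2)nc(N[C@@H]2C[C@H](CO)[C@@H](O)[C@H]2O)c1-c1nc2cnccc2s1` and compound 2 `Cc1ccc([C@@H](C)Nc2nc(C)c(-c3nc4cnccc4s3)c(N[C@@H]3C[C@H](CO)[C@@H](O)[C@H]3O)n2)cc1` share one core and differ only in methyl in place of hydrogen on an aromatic carbon, which gives a 1.9-fold lower number from compound 1 to compound 2 (0.29 log units; within the scatter) in an ADME assay on the whole organism (plasma) for pharmacokinetics, with Rattus norvegicus as the target, with a stated time of 6 h, at a dose of 10 mg/kg by the oral route; a higher number here means more compound in the circulation at the dose given, a lower number less compound in the circulation; compound 1 gives 98.5 ng.h/mL and compound 2 gives 50.7 ng.h/mL. Compound 3 `Cc1cc2sc(-c3c(C)nc(N[C@H](C)c4ccc(OC(F)(F)F)cc4)nc3N[C@@H]3C[C@H](CO)[C@@H](O)[C@H]3O)nc2cn1` carries a different core; the difference between the two cores is not broken down here, and in this assay compound 3 gives "not determined" (no result reported), so it has no single number there. Compound 4 `Cc1cc2sc(-c3c(C)nc(N[C@H](C)c4ccc(OC(F)(F)F)cc4)nc3N[C@@H]3C[C@H](CO)[C@@H](O)[C@H]3O)nc2c(C)n1` differs from compound 3 by methyl in place of hydrogen on an aromatic carbon, the same kind of change as in the measured pair, but the methyl now enters on a six-membered aromatic ring with one nitrogen in a fused system, next to the ring nitrogen, ortho and meta to a fused ring and meta to a methyl group, rather than on a ring of carbon only, para to a large group. A small step is expected because the earlier step of a 1.9-fold lower number from compound 1 to compound 2 (0.29 log units; within the scatter) stayed within the scatter, though with no number for compound 3 the expectation rests on compounds 1 and 2 alone. Compound 4 is expected to give about 60 ng.h/mL, likely between 15 ng.h/mL and 240 ng.h/mL.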

Compound 4, area under the concentration-time curve: 3390 ng.h/mL
Beside the measured number, compound 4's estimate is 57-fold (1.75 log units) below it, and the stated range ends below it.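

For the compounds shown here, compound 3 has no single number to set against compound 4, so no step between them can be read. The compounds shown leave open how much of compound 4's [ 3390 ng.h/mL ] goes with the added methyl, and no data here bear on a cause.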